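The source may hold more compounds than are shown below. What is called first, only, known or untested is meant among the compounds shown, and "the series" means these compounds.

Among the compounds with values here, compound 1 `Cn1c(CN2CCC(c3ccccc3)CC2)nc2ccccc21` is the one compound here that gives a number: in an assay on CHO cells with metabotropic glutamate receptor 2 (Homo sapiens) as the target, read by FLIPR (on this read-out lower numbers stand for an effect already at smaller amounts and higher numbers for an effect only at larger amounts of compound), compound 1 gives 200 nM. The second measured compound, compound 2 `Cn1c(CN2CCC(c3ccccn3)CC2)nc2ccccc21`, gives in this assay only > 3160 nM, which is a limit of the assay and not a number, matching (the limit of > 3160 nM in this assay, at which 1 of the 2 values shown sits). Within the data shown here, the single measured step, an at least 15-fold higher number from compound 1 to compound 2 (1.19 log units; beyond the scatter), comes from putting pyridin-2-yl in place of phenyl on a saturated ring carbon.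

Compound 3 `Cn1c(CN2CCC(c3ccccc3C(F)(F)F)CC2)nc2ccccc21` keeps the phenyl of compound 1 and changes it elsewhere: trifluoromethyl in place of hydrogen on an aromatic carbon. Among the measured compounds shown here, no measured step touches this aromatic carbon, so the large step from compound 1 to compound 2 does not bear on it directly; it only shows that the ring hanging from the saturated ring carbon is sensitive to change. With no closer guide, a step in this assay of modest size is expected for compound 3, slightly toward larger amounts, and perhaps within the scatter: a 1.6-fold higher number from compound 1 to compound 3 (0.20 log units; within the scatter). In this assay compound 3 is therefore estimated at 320 nM, between 100 nM and 1600 nM.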

Compound 3, half-maximal effective concentration: 316 nM
Compound 3: middle estimate off by 1.0-fold (0.01 log units), on the high side; the range from low to high includes it.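

In this assay the step is a 1.6-fold higher number from compound 1 to compound 3 (0.20 log units; within the scatter), so compound 1 and compound 3 cannot be told apart on this read-out, and the phenyl ring can carry a trifluoromethyl group on an aromatic carbon, ortho to a large group, with no measurable difference from the hydrogen it replaces. Set against the large step seen with compound 2, this shows that the ring hanging from the saturated ring carbon does not respond to every alteration: exchanging the phenyl for pyridin-2-yl is beyond the scatter, whereas this added group on the phenyl is not. Nothing measured here gives a reason for this tolerance.

The compounds shown leave open whether this aromatic carbon would accept other groups just as well, such as a methoxy group, a chlorine atom, an amine or a carboxylic acid, and whether trifluoromethyl would give the same result on the other aromatic carbons of the ring. They also leave open whether any group on this ring can take the number below that of compound 1, since a single substituted example cannot show a trend.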